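From compound 1 to compound 3: a new aromatic group

A few compounds are considered here, and "the series" means these few. Any claim that something is new, unique, unknown or untested is made for them only; others in the source may bear on it.

Compound 1 `CC(=O)Nc1n[nH]c2cc(-c3cn([C@@H]4CN[C@H](C(=O)Nc5ccc(Cl)c(C(F)(F)F)c5)C4)nn3)ccc12`: 15500 nM 
Compound 2 `O=C(Nc1n[nH]c2cc(-c3cn([C@@H]4CN[C@H](C(=O)Nc5ccc(Cl)c(C(F)(F)F)c5)C4)nn3)ccc12)C1CC1`: 5200 nM 

In a functional assay on K562 cells (Homo sapiens) for inhibition, read by MTT assay, with a stated time of 48 h (a lower number here means a stronger inhibitor, a higher number a weaker inhibitor), compound 1 stands highest of the two measured compounds, at 15500 nM as the weaker inhibitor. Compound 3 `CC(=O)Nc1n[nH]c2cc(-c3cn([C@@H]4CN[C@H](C(=O)Nc5ccc(Br)cc5)C4)nn3)ccc12` keeps the core of compound 1 but carries 4-bromophenyl in place of 4-chloro-3-(trifluoromethyl)phenyl on an amide-type nitrogen. Going by the values given here, the only measured step is a 3.0-fold lower number from compound 1 to compound 2 (0.47 log units; beyond the scatter) and is modest, yet it concerns a different change: cyclopropyl in place of methyl on a carbonyl carbon. Among the compounds with values here, it hints at a possible size, but no measured step gives a direction for this swap. The expected change is a 1.0-fold lower number from compound 1 to compound 3 (0.01 log units; within the scatter) with wide uncertainty either way. Compound 3 is estimated at 15000 nM (range 6000 nM to 40000 nM).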

Compound 3, half-maximal inhibitory concentration: 3830 nM
For compound 3 the middle estimate is 3.9-fold (0.59 log units) above the measured one, and the stated range ends above it.
By their numbers in this assay, from the lowest: compounds 3 and 2 (each within the scatter of the next); then compound 1.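

Changing the aromatic group on the amide-type nitrogen also shifts the result in this assay, with a 4.0-fold lower number from compound 1 to compound 3 (0.61 log units; beyond the scatter), so this part of the molecule matters as well as the group on the carbonyl carbon. The swap removes trifluoromethyl and replaces chlorine with bromine in one step, so it cannot show which of these changes counts. No measured evidence here explains the shift.

Going by these compounds, it remains open whether bromine itself matters, which plain phenyl or 4-methoxyphenyl on the same nitrogen could test. On these data alone, it is also open whether 4-bromophenyl and the cyclopropyl group of compound 2 would work together in one molecule.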